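The source may report more compounds than this note shows. Statements on the series, on what has been measured and on what is new or still open speak of the compounds shown alone.

Compound 3 `COC(=O)/C=C/c1cccc(N(Cc2ccccc2)C(=O)C2CCCCC2)c1` gives, in an assay on isolated protein with Bile acid receptor (Homo sapiens) as the target (on this read-out lower numbers stand for an effect already at smaller amounts and higher numbers for an effect only at larger amounts of compound), a result of > 1000 nM, which is a limit of the assay rather than a number (the limit of > 1000 nM in this assay, at which 1 of the 3 values shown sits). Of the compounds measured, it is the one that reaches that limit.

Compound 4 `COC/C=C/c1ccc(CN(C(=O)C2CCCCC2)c2cccc(/C=C/C(=O)OC)c2)cc1` differs from compound 3 only in one place: 3-methoxyprop-1-en-1-yl in place of hydrogen on an aromatic carbon.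

Two measured steps point to what this position does. Compound 1 `COC(=O)/C=C/c1cccc(N(Cc2ccc(/C=C/c3scnc3C)cc2)C(=O)C2CCCCC2)c1` carries a 2-(4-methyl-1,3-thiazol-5-yl)ethenyl group there and gives 227 nM; removing it gave an at least 4.4-fold higher number from compound 1 to compound 3 (0.64 log units; beyond the scatter). Compound 2 `COC(=O)/C=C/c1cccc(N(Cc2ccc(-c3cccc(Cl)c3)cc2)C(=O)C2CCCCC2)c1` carries a 3-chlorophenyl group there and gives 94 nM; removing it gave an at least 10-fold higher number from compound 2 to compound 3 (1.02 log units; beyond the scatter). In both cases a group at this position lowered the number, and taking it away raised it past the limit. The incoming 3-methoxyprop-1-en-1-yl group is a short chain with no ring, unlike the two groups measured so far, so the size of the gain is uncertain.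

Compound 4 is therefore expected to come back below the limit, with an estimated step of an at least 2.2-fold lower number from compound 3 to compound 4 (0.34 log units; beyond the scatter), giving an estimate of 450 nM with a range of 150 nM to 1500 nM.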

Compound 4, half-maximal effective concentration: 233 nM
Compound 4: middle estimate off by 1.9-fold (0.29 log units), on the high side; low and high end bracket the measured number.
By their numbers in this assay, from the lowest: compound 2; then compounds 1 and 4 (each within the scatter of the next). At a limit, above all of these: compound 3.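

Compound 3 in this assay stands at a limit, not at a number: the limit of > 1000 nM in this assay, at which 1 of the 4 values shown sits. The short 3-methoxyprop-1-en-1-yl chain, which has no ring, is enough to bring the number back under that limit, with an at least 4.2-fold lower number from compound 3 to compound 4 (0.63 log units; beyond the scatter), so the gain at this position does not need a ring in the group. Putting methoxymethyl in place of 4-methyl-1,3-thiazol-5-yl on the double-bonded chain makes no difference that can be told apart, with a 1.0-fold higher number from compound 1 to compound 4 (0.01 log units; within the scatter), while the chain does fall short of the 3-chlorophenyl group, with a 2.5-fold higher number from compound 2 to compound 4 (0.39 log units; beyond the scatter).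

On these data alone, whether the chain's oxygen or its double bond matters stays open: a saturated 3-methoxypropyl chain or a plain prop-1-en-1-yl chain would separate the two. As far as these compounds go, how an amine or a carboxylic acid at the chain's end, or a longer chain, would compare also remains open.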